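The source may hold more compounds than are shown below. What is called first, only, known or untested is meant among the compounds shown, and "the series" means these compounds.

In an ADME assay on microsomes from liver (Homo sapiens) for metabolic stability, read by LC-MS, using NADPH, with a stated time of 10 min, tested at 10 uM (on this read-out lower numbers stand for a shorter-lived compound and higher numbers for a longer-lived compound), three compounds that share one core differ only in the group on an aromatic nitrogen. Compound 1 `Nc1ncnc2c1c(Oc1cc(C(F)(F)F)ccn1)nn2[C@H]1CC[C@H](CO)CC1` gives > 2.41 h, which is a limit of the assay and not a number. Compound 2 `CO[C@H]1CC[C@@H](n2nc(Oc3cc(C(F)(F)F)ccn3)c3c(N)ncnc32)CC1` gives 0.317 h. Compound 3 `Nc1ncnc2c1c(Oc1cc(C(F)(F)F)ccn1)nn2[C@H]1C[C@H](F)C1` gives 2.03 h, the higher of the two actual numbers, and the gap between them is a 6.4-fold higher number from compound 2 to compound 3 (0.81 log units; beyond the scatter).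

Compound 4 `Nc1ncnc2c1c(Oc1cc(C(F)(F)F)ccn1)nn2[C@@H]1CC[C@H](N)C1` has 3-aminocyclopentyl in place of 3-fluorocyclobutyl on an aromatic nitrogen. All three measured steps change this same group, although none brings in 3-aminocyclopentyl, so they offer only indirect guidance. Only compound 2, with 4-methoxycyclohexyl, sits low, as an at least 7.6-fold lower number from compound 1 to compound 2 (0.88 log units; beyond the scatter) shows. By contrast, an at least 1.1-fold lower number from compound 1 to compound 3 (0.07 log units; that floor lies within the scatter) leaves compound 3 close to the limit reached by compound 1. Compound 4 has no methoxy group, so no step beyond the scatter is expected in this assay, although this remains uncertain. The expected change is a 1.0-fold lower number from compound 3 to compound 4 (0.01 log units; within the scatter). The estimated half-life of compound 4 is 2 h, within a range of 0.8 h to 4.5 h.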

Compound 4, half-life: > 2.41 h
Compound 4 was reported as a limit; the forecaster's own chance of this, stated with the estimate: 40%; at least 1.2-fold (0.08 log units) between middle value and limit.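

In this assay, among these compounds, compound 4 gives > 2.41 h, which is a limit of the assay and not a number, so this aromatic nitrogen can carry 3-aminocyclopentyl, the first group here with an amine, and the half-life stays long. Among the compounds shown here, the change from 3-fluorocyclobutyl shows no step beyond the scatter, an at least 1.1-fold higher number from compound 3 to compound 4 (0.07 log units; that floor lies within the scatter), whereas the gap to the methoxy compound is clear, an at least 7.6-fold higher number from compound 2 to compound 4 (0.88 log units; beyond the scatter), leaving compound 2 as the only short-lived compound of the four. Compound 1 and compound 4 cannot be read against each other, because both are reported as limits: the limit of > 2.41 h in this assay, at which 2 of the 4 values shown sit.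

From the compounds shown here alone, whether the amine or the five-membered ring matters more remains open. It is also unclear whether a methoxy group on a cyclopentyl ring, or an amine on a cyclohexyl ring, would read as low as compound 2 does.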